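The source may hold more compounds than are shown below. What is called first, only, known or untested is meant among the compounds shown, and "the series" means these compounds.

In a functional assay for inhibition, with Rattus norvegicus as the target (on this read-out higher numbers stand for weaker inhibition and lower numbers for stronger inhibition), compound 1 `CC(/N=c1\c(O)c(O)\c1=N/c1ccc(Br)cc1)C(C)(C)C` gives 1260 nM. Compound 2 `CC(/N=c1\c(O)c(O)\c1=N/c1ccc(S(N)(=O)=O)cc1)C(C)(C)C` gives only a limit, > 30000 nM. Compound 3 `CC(=O)c1ccc(/N=c2\c(O)c(O)\c2=N/C(C)C(C)(C)C)cc1` gives 21200 nM, the higher of the two actual numbers. Compound 4 `CC(/N=c1\c(O)c(O)\c1=N/c1ccc(-c2ccccc2)cc1)C(C)(C)C` carries phenyl in place of acetyl on an aromatic carbon, para to a large group (phenyl in place of acetyl on an aromatic carbon). Within the data shown here, three measured steps concern this same place. Leaving bromo was costly both ways, with an at least 23-fold higher number from compound 1 to compound 2 (1.37 log units; beyond the scatter) and a 17-fold higher number from compound 1 to compound 3 (1.23 log units; beyond the scatter), both large, while an at least 1.4-fold lower number from compound 2 to compound 3 (0.15 log units; that floor lies within the scatter) has a floor within the scatter. Phenyl resembles neither acetyl nor sulfamoyl, so a large move back towards compound 1 at 1260 nM is expected, though probably not all the way. The expected step is a 7.1-fold lower number from compound 3 to compound 4 (0.85 log units; beyond the scatter). For compound 4 the estimate is 3000 nM, with an expected range of 700 nM to 15000 nM.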

Compound 4, half-maximal inhibitory concentration: > 30000 nM
Compound 4: a limit, no number; the forecaster's own chance of this, stated with the estimate: 10%; middle value at least 10-fold (1.00 log units) away from the limit.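

In this assay compound 4 gives > 30000 nM, which is a limit and not a number. Phenyl holds no oxygen, yet an at least 23-fold higher number from compound 1 to compound 4 (1.37 log units; beyond the scatter), so at this aromatic carbon the loss relative to bromo is not confined to the oxygen-bearing replacements acetyl and sulfamoyl. Against acetyl, an at least 1.4-fold higher number from compound 3 to compound 4 (0.15 log units; that floor lies within the scatter), so no order between the two groups can be claimed.

The step between compound 2 and compound 4 cannot be read, as both values are limits: the limit of > 30000 nM in this assay, at which 2 of the 4 values shown sit. Going by these compounds, whether chloro or methyl on this carbon would stay close to compound 1 remains open.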